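The compounds below may be only part of what the source reports. "The series", "measured", "known", "first", "only" and "open" are said of these compounds alone.

Measured to date in an ADME assay on HepG2 2.2.15 cells (Homo sapiens) for cytotoxicity, read by MTT assay, with stated times of 48 h and 9 days; on this read-out higher numbers stand for lower toxicity in this test and lower numbers for higher toxicity in this test:
compound 1 `COc1ccc2c(=O)c(/C=C/C(=O)Nc3cccc(C)c3)coc2c1` gives 554000 nM
compound 2 `COc1ccc2c(=O)c(/C=C/C(=O)Nc3cccc(Cl)c3)coc2c1` gives 1100000 nM
compound 3 `COc1ccc2c(=O)c(/C=C/C(=O)Nc3ccccc3)coc2c1` gives 523000 nM

Compound 3 holds the lowest number of the three, though its gap to compound 1 is within the scatter; only compound 2 stands apart, by a 2.1-fold lower number from compound 2 to compound 3 (0.32 log units; beyond the scatter).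

Compound 4 `COc1ccc2c(=O)c(/C=C/C(=O)Nc3ccccc3Cl)coc2c1` differs from compound 3 by chloro in place of hydrogen on an aromatic carbon. Going by the values given here, the one step touching a chloro, a 2.1-fold lower number from compound 2 to compound 3 (0.32 log units; beyond the scatter), concerns a chloro on another carbon of that ring, so it bears only loosely here, and a 2.0-fold higher number from compound 1 to compound 2 (0.30 log units; within the scatter) adds little beyond the scatter. A modest rise in this assay is therefore expected, of about a 1.5-fold higher number from compound 3 to compound 4 (0.18 log units; within the scatter). Compound 4 is estimated at 800000 nM, between 400000 nM and 1600000 nM.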

Compound 4, half-maximal cytotoxic concentration: 1010000 nM
Beside the measured number, compound 4's estimate is 1.3-fold (0.10 log units) below it, within the range that was stated.
By their numbers in this assay, from the lowest: compounds 3, 1, 4 and 2 (each within the scatter of the next, the first and the last beyond it).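

In this assay, chloro in place of hydrogen on this aromatic carbon, ortho to a large group, stays within the scatter (a 1.9-fold higher number from compound 3 to compound 4 (0.29 log units; within the scatter)), whereas the 3-chlorophenyl compound stood beyond it from the parent (a 2.1-fold lower number from compound 2 to compound 3 (0.32 log units; beyond the scatter)). Yet 2-chlorophenyl and 3-chlorophenyl cannot be told apart (a 1.1-fold lower number from compound 2 to compound 4 (0.04 log units; within the scatter)), and 2-chlorophenyl and 3-methylphenyl also remain within the scatter of each other (a 1.8-fold higher number from compound 1 to compound 4 (0.26 log units; within the scatter)). No supporting evidence bears on these numbers. Open, going by these compounds, is how an amine or a carboxylic acid on this same carbon would read.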